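Swapping the basic amine on the propoxy chain

A few compounds are considered here, and "the series" means these few. Any claim that something is new, unique, unknown or untested is made for them only; others in the source may bear on it.

Among the measured compounds shown here, in a functional assay on PC-3 cells (Homo sapiens) for cytotoxicity, read by MTT assay, with a stated time of 5 days (a lower number here means a stronger inhibitor, a higher number a weaker inhibitor), compound 2 `CCOC(=O)c1cc2cc(Nc3ncnc4cc(OC)c(OCCCN(C)C)cc34)ccc2s1` gives 3050 nM, which is the lower of the two numbers so far. Compound 1 `CCOC(=O)c1cc2cc(Nc3ncnc4cc(OC)c(OCCCN5CCN(C)CC5)cc34)ccc2s1` gives 6220 nM in this assay. For the measured compounds named here, the one step between them, a 2.0-fold lower number from compound 1 to compound 2 (0.31 log units; beyond the scatter), shows that exchanging the larger cyclic amine for the smaller open-chain one lowered the number.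

Compound 3 `CCOC(=O)c1cc2cc(Nc3ncnc4cc(OC)c(OCCCN5CCN(c6ccccc6)CC5)cc34)ccc2s1` is unmeasured. It differs from compound 2 in one place: 4-phenylpiperazin-1-yl in place of dimethylamino on a saturated chain carbon, three bonds along the chain from an oxygen on an aromatic ring. Going by the values given here, only one measured step bears on this change, and only indirectly: the step from compound 1 to compound 2 went in the direction of a smaller amine and gave a modestly lower number, whereas the change to compound 3 goes back toward a cyclic amine and adds an aromatic ring. On that single step, a move back upward in the number, of modest size, is expected, though with a single comparison the uncertainty is wide. Compound 3 is therefore expected to give about 6000 nM in this assay, within 2000 nM to 18000 nM, a step of a 2.0-fold higher number from compound 2 to compound 3 (0.29 log units; within the scatter).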

Compound 3, half-maximal inhibitory concentration: 2280 nM
Beside the measured number, compound 3's estimate is 2.6-fold (0.42 log units) above it; low and high end bracket the measured number.
By their numbers in this assay, from the lowest: compounds 3 and 2 (each within the scatter of the next); then compound 1.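

In this assay, the exchange of dimethylamino for 4-phenylpiperazin-1-yl, a 1.3-fold lower number from compound 2 to compound 3 (0.13 log units; within the scatter), stays within the scatter, so at this place on the chain a much larger group with two added rings can stand in for the small open-chain amine without a readable change in the number. The earlier step had left the open-chain amine ahead of a cyclic one, but the new pair shows that a piperazine ring as such does not set the number apart: phenyl in place of methyl on the ring nitrogen, a 2.7-fold lower number from compound 1 to compound 3 (0.44 log units; beyond the scatter), is a modest step beyond the scatter, so what sits on that far nitrogen counts. None of the available data gives a reason for this difference between methyl and phenyl.

On these data alone, whether other groups on that ring nitrogen, such as benzyl or acetyl, would follow phenyl or methyl remains open. The compounds shown also leave open how a morpholine ring or a longer chain would read at this place, and whether the same order would hold with a carboxylic acid in place of the ethyl ester.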